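Chain Methylation on the Trifluoromethyl Analogue: Compound 4

The source may report more compounds than this note shows. Statements on the series, on what has been measured and on what is new or still open speak of the compounds shown alone.

Compound 1 `CC(C(=O)N1CCN(c2ccccc2)CC1)N1C(=O)CCC1=O` gives 100% in a functional assay on the whole organism (strain Swiss) with Mus musculus as the target, in the maximal electroshock model, with a stated time of 0.25 h, at a dose of 300 mg/kg by the intraperitoneal route; on this read-out higher numbers stand for a stronger effect at the one dose given and lower numbers for a weaker effect.
Compound 2 `CC(C(=O)N1CCN(c2ccc(Cl)cc2)CC1)N1C(=O)CCC1=O` gives 100% in this assay.
Compound 3 `CC(C(=O)N1CCN(c2ccc(C(F)(F)F)cc2)CC1)N1C(=O)CCC1=O` gives 25% in this assay.

Compound 3 stands lowest of the three, as shown by a number 75 percentage points lower from compound 1 to compound 3 (beyond the scatter) and a number 75 percentage points lower from compound 2 to compound 3 (beyond the scatter), whereas no change at the digits printed from compound 1 to compound 2 (within the scatter). Compound 4 `CCC(C(=O)N1CCN(c2ccc(C(F)(F)F)cc2)CC1)N1C(=O)CCC1=O` differs from compound 3 in one place: methyl in place of hydrogen on a saturated chain carbon, two bonds along the chain from an amide-type nitrogen in a ring and a carbonyl carbon. Among the measured compounds shown here, all three measured steps concern only the substituent on the aromatic ring; none touches the saturated chain, so no measured step bears directly on this change. The expectation for compound 4 in this assay therefore rests on compound 3 alone and is of no step beyond the scatter, with wide uncertainty. Compound 4 is accordingly estimated to give 25%, with a range from 0% to 75%. The step this estimate implies, no change at the digits printed from compound 3 to compound 4 (within the scatter), is expected to stay within the scatter.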

Compound 4, a percentage reported as activity, at one dose (the size of the read-out at that dose, not a potency): 25%
Compound 4: middle estimate and measured number agree at the digits printed, within the range that was stated.
By their numbers in this assay, from the lowest: compounds 3 and 4 (each within the scatter of the next); then compounds 1 and 2 (each within the scatter of the next).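

Among the compounds shown here, compounds 1 to 3 differ only in the substituent on the aromatic ring, so this is the first reading of a change on the saturated chain: with methyl in place of hydrogen at this carbon, the step reads no change at the digits printed from compound 3 to compound 4 (within the scatter) in this assay. On the trifluoromethyl analogue, the methyl to ethyl change therefore leaves the read-out within the scatter. No measured information bears on the reason for this result.

As far as these compounds go, whether the same change behaves alike on the unsubstituted or chloro analogue stays open. So does the effect of a longer chain, such as propyl, or an amine at this carbon.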